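Lengthening the selenium-bearing arm of compound 3

The compounds below may be only part of what the source reports. "The series", "measured", "known", "first", "only" and "open" are said of these compounds alone.

Of the compounds shown here, three of this set have been measured in a functional assay on A-431 cells (Homo sapiens) for cytotoxicity, read by MTT assay, with a stated time of 24 h; a lower number here means a stronger inhibitor, a higher number a weaker inhibitor. Compound 1 `CC1=C([Se]CC(OC(=O)CC[Se]c2ccccc2)C(=O)NCCCCCC(=O)OCc2ccccc2)C(=O)c2ccccc2C1=O` gives 4000 nM. Compound 2 `CC1=C(SCCC(=O)OC(C[Se]C2=C(C)C(=O)c3ccccc3C2=O)C(=O)NC(C)(C)C)C(=O)c2ccccc2C1=O` gives 1000 nM. Compound 3 `CC1=C(SCCC(=O)OC(C[Se]c2ccccc2)C(=O)NC(C)(C)C)C(=O)c2ccccc2C1=O` gives 7000 nM, the highest of the three numbers; its gap to compound 1 lies within the scatter, whereas its gap to compound 2 lies beyond it, so only compound 2 is clearly set apart from compound 3.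

Compound 4 `CC1=C(SCCC(=O)OC(CC[Se]c2ccccc2)C(=O)NC(C)(C)C)C(=O)c2ccccc2C1=O` has not yet been measured in this assay. It differs from compound 3 in one place: a group of 8 heavy atoms (7 carbon, 1 selenium; one six-membered aromatic ring of carbon only) in place of a group of 7 heavy atoms (6 carbon, 1 selenium; one six-membered aromatic ring of carbon only), on a saturated chain carbon, two bonds along the chain from a carbonyl carbon and an oxygen next to a carbonyl group. The change adds a single carbon to the saturated chain while keeping the selenium and the aromatic ring, and nothing elsewhere in the set shows what such a change does.

Within the data shown here, with no comparable step among the measured compounds, the account expects the step of a 1.2-fold lower number from compound 3 to compound 4 (0.07 log units; within the scatter) to be small, with no direction beyond the scatter. Compound 4 is therefore estimated at 6000 nM, in a range from 2500 nM to 15000 nM.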

Compound 4, half-maximal inhibitory concentration: > 100000 nM
Compound 4 was reported as a limit; the forecaster's own chance of this, stated with the estimate: 10%; middle value at least 16-fold (1.22 log units) away from the limit.
By their numbers in this assay, from the lowest: compound 2; then compounds 1 and 3 (each within the scatter of the next). At a limit, above all of these: compound 4.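

In this assay, among these compounds, one added carbon on the saturated chain that keeps the selenium and the aromatic ring gives an at least 14-fold higher number from compound 3 to compound 4 (1.15 log units; beyond the scatter), so this place, on a saturated chain carbon, two bonds along the chain from a carbonyl carbon and an oxygen next to a carbonyl group, proves highly sensitive to this small change, which no earlier pair could show. Compound 4 stands at > 100000 nM, which is a limit of the assay and not a number. The size of the step is therefore bounded from one side only: the limit of > 100000 nM in this assay, at which 1 of the 4 values shown sits.

The compounds shown leave open whether a longer chain at this place would also stay at such a limit, or whether a sulfur atom in place of the selenium would restore a measurable number. They also leave open whether the added carbon would act in the same way on compound 2.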